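Coumarin-3-carboxamide series: amide substituent and HCT-116 cytotoxicity

The source may report more compounds than this note shows. Statements on the series, on what has been measured and on what is new or still open speak of the compounds shown alone.

Measured so far:
Compound 1 `O=C(NCCO)c1cc2ccc(OCc3ccccc3)cc2oc1=O` gives in a functional assay on HCT-116 cells (Homo sapiens) for cytotoxicity, read by MTT assay, with a stated time of 72 h (on this read-out lower numbers stand for stronger inhibition and higher numbers for weaker inhibition), a value of 18700 nM.
Compound 2 `O=C(Nc1ccccc1)c1cc2ccc(OCc3ccccc3)cc2oc1=O` gives in this assay only a limit, > 100000 nM.

Compound 2 thus stands at the edge of what this assay can report; its value is a limit and not a number, and among the two values shown it is the one sitting at the limit of > 100000 nM in this assay, at which 1 of the 2 values shown sits. The step that led there, an at least 5.3-fold higher number from compound 1 to compound 2 (0.72 log units; beyond the scatter), is the only one measured.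

Compound 3 `O=C(NO)c1cc2ccc(OCc3ccccc3)cc2oc1=O` carries the change (hydroxy in place of phenyl on an amide-type nitrogen). This reverses the direction of that measured step: a small polar group replaces the phenyl on the amide-type nitrogen, much as the 2-hydroxyethyl of compound 1 had stood there. A drop in the number, at least modest, is therefore expected in this assay. The expected step is an at least 10-fold lower number from compound 2 to compound 3 (1.00 log units; beyond the scatter). For compound 3 the estimate is 10000 nM, with a range from 2000 nM to 60000 nM.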

Compound 3, half-maximal inhibitory concentration: 39500 nM
Compound 3: the middle estimate sits 4.0-fold (0.60 log units) below what was measured; low and high end bracket the measured number.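

On the amide-type nitrogen, hydroxy gives a measurable value in this assay where phenyl does not, the step reading an at least 2.5-fold lower number from compound 2 to compound 3 (0.40 log units; beyond the scatter). The value of compound 2 is a limit and not a number, so the true size of this step stays unknown: the limit of > 100000 nM in this assay, at which 1 of the 3 values shown sits.
Hydroxy does not simply stand in for 2-hydroxyethyl, since the step reads a 2.1-fold higher number from compound 1 to compound 3 (0.32 log units; beyond the scatter), leaving compound 1 with the lowest number of the three.

From the compounds shown here alone, it remains open whether the lower number of compound 1 depends on the chain or on its terminal hydroxy, which a plain ethyl, a 2-aminoethyl or a longer chain ending in hydroxy on the same nitrogen would help to separate. Going by these compounds, it is also open whether aromatic rings other than phenyl, such as pyridyl, behave as phenyl does here.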